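Series notes: cyclohexyl for 3-hydroxyphenyl on the aryl-amine core

The compounds below may be only part of what the source reports. "The series", "measured", "known", "first", "only" and "open" are said of these compounds alone.

Measured compounds:
- compound 1 `Oc1ccccc1CNc1ccc(N2CCCCC2)cc1`: "not active" (no number reported)
- compound 2 `Oc1ccccc1CNc1ccc(-c2ccc(Cl)cc2)cc1`: 2390 nM
- compound 3 `Oc1cccc(-c2ccc(NCc3ccccc3O)cc2)c1`: "not active" (no number reported)

In a functional assay on Jurkat cells (Homo sapiens) for activation, with a stated time of 24 h (a higher number here means that more compound is needed for the effect, a lower number that less compound is needed), compound 3 gives "not active" (no number reported), so no single number stands for it. Compound 1 likewise gives "not active" (no number reported) in this assay, a second entry without a number. Within the data shown here, the only compound with a numerical read-out is compound 2, which gives 2390 nM in this assay. Compound 3 therefore cannot be placed against compound 2 on a numerical scale; all that the data show is that compound 2 produced a half-maximal effective concentration and compound 3 did not.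

Compound 4 `Oc1ccccc1CNc1ccc(C2CCCCC2)cc1` has not been measured. The change from compound 3 is cyclohexyl in place of 3-hydroxyphenyl on an aromatic carbon. Among the measured compounds shown here, no step between measured compounds covers this change, and compound 3 itself has no number from which a step could be counted. For the measured compounds named here, the expectation is set by the surrounding entries: two of the three measured compounds gave no number, and the one number, that of compound 2, lies in the micromolar range. For compound 4 a weak or absent response is expected, with a substantial chance that only a limit is reported. Compound 4 is estimated at 6000 nM in this assay, in the range 1500 nM to 25000 nM.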

Compound 4, half-maximal effective concentration: 8800 nM
Beside the measured number, compound 4's estimate is 1.5-fold (0.17 log units) below it; the measured number falls inside the stated range.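

With cyclohexyl on this aromatic carbon, compound 4 gives a numerical read-out in this assay, whereas the 3-hydroxyphenyl of compound 3 gives none, so among the compounds shown, an aromatic ring at this place is not needed for a half-maximal effective concentration to be reached. The aromatic ring does not guarantee a number either, as compound 3 shows, while the pair with 4-chlorophenyl reads the other way: cyclohexyl in place of 4-chlorophenyl gives a 3.7-fold higher number from compound 2 to compound 4 (0.57 log units; beyond the scatter), so compound 2 keeps the lower number of this pair. No measurement offers an explanation for either difference.

Open, on these data alone, is how an unsubstituted phenyl or a 4-methoxyphenyl would read at this place, which would help separate the contribution of the ring from that of the chlorine in compound 2 and the hydroxyl in compound 3. Also open, as far as these compounds go, is whether an open chain such as n-hexyl, or a group carrying a carboxylic acid or an amine, would give a number at this position.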